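A few compounds are considered here, and "the series" means these few. Any claim that something is new, unique, unknown or untested is made for them only; others in the source may bear on it.

Measured so far:

- compound 1, `NC(N)=NC(=O)c1nc(Cl)c(NCc2ccccc2Cl)nc1N`: 90%
- compound 2, `NC(N)=NC(=O)c1nc(Cl)c(NCC2CCCCC2)nc1N`: 96%

Both compounds share the same core and differ only in the group carried on the saturated chain carbon bound to the ring nitrogen. In an assay for inhibition of acid-sensing ion channel 3 (Homo sapiens), read by patch clamp, tested at 20 uM (a higher number here means more inhibition at the concentration tested (going by the name of the read-out), a lower number less inhibition), compound 1 gives 90% and compound 2 gives 96%. Among the measured compounds shown here, the single step, a number 6 percentage points higher from compound 1 to compound 2 (within the scatter), is within the scatter, so on the numbers available compound 2 stands beside compound 1 rather than apart from it; the two numbers are level.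

Compound 3, `NC(N)=NC(=O)c1nc(Cl)c(Nc2ccccn2)nc1N`, is the next compound. Its change against compound 2 is pyridin-2-yl in place of cyclohexylmethyl on a nitrogen on an aromatic ring. For the measured compounds named here, the only measured step, a number 6 percentage points higher from compound 1 to compound 2 (within the scatter), altered the ring carried on the chain carbon and left the chain in place; no measured pair removes the chain or puts an aromatic ring directly on the ring nitrogen. That step therefore bears on the new change only loosely, and the data give no direct basis for the size of the step in this assay from compound 2 to compound 3.

The estimate for compound 3 in this assay is 70%, with a range of 35% to 95%, which corresponds to an expected step of a number 26 percentage points lower from compound 2 to compound 3 (beyond the scatter).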

Compound 3, a percentage reported as inhibition, at one concentration (the size of the read-out at that concentration, not a potency): 25%
Compound 3: middle estimate off by 45 percentage points, on the high side; the whole stated range lies above it.
By their numbers in this assay, from the lowest: compound 3; then compounds 1 and 2 (each within the scatter of the next).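

Among the compounds shown here, replacing cyclohexylmethyl with pyridin-2-yl on a nitrogen on an aromatic ring gives, in this assay, a step of a number 71 percentage points lower from compound 2 to compound 3 (beyond the scatter), the first step to lie beyond the scatter. For the compounds shown here, the earlier change, a number 6 percentage points higher from compound 1 to compound 2 (within the scatter), left the chain in place and showed only that two different rings on the saturated chain carbon give level numbers; this result shows that the read-out at this position can also move a long way. The new change alters several things at once, as the saturated chain carbon leaves, the non-aromatic carbon ring gives way to an aromatic ring, and a hetero atom enters, and nothing measured here accounts for the size of the step.

From the compounds shown here alone, it remains open which of these differences carries the step, since the chain, the aromatic character and the ring nitrogen all change together in this single pair. Going by these compounds, a pyridin-2-ylmethyl or a phenyl group on the same nitrogen would separate them, and the response to a longer chain or to an amine at the end of the chain also remains unknown.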